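Adding an isopropyl group to compound 3

This account rests on a few compounds, and the source may have more. Where it says the series, first, only, none or still open, it means among the compounds named here.

Compound 1 `Cc1ccc(-c2ccsc2S(=O)(=O)NCCNC(=O)Nc2cc(C(F)(F)F)cc(C(F)(F)F)c2)c(Oc2ccc(O)c(O)c2)c1` gives 5600 nM
Compound 2 `O=[N+]([O-])c1ccc(Oc2ccccc2-c2ccc(S(=O)(=O)NCCNC(=S)Nc3cc(C(F)(F)F)cc(C(F)(F)F)c3)s2)cc1` gives 6300 nM
Compound 3 `O=C(NCCNS(=O)(=O)c1sccc1-c1ccccc1Oc1ccc(O)c(O)c1)Nc1cc(C(F)(F)F)cc(C(F)(F)F)c1` gives 4900 nM

In a functional assay on RS4-11 cells (Homo sapiens) for inhibition, read by CCK-8 assay, with a stated time of 48 h (a lower number here means a stronger inhibitor, a higher number a weaker inhibitor), compound 3 gives 4900 nM and lies within the scatter of compound 1 and compound 2, so the three cannot be ranked. Compound 4 `CC(C)c1ccc(Oc2ccc(O)c(O)c2)c(-c2ccsc2S(=O)(=O)NCCNC(=O)Nc2cc(C(F)(F)F)cc(C(F)(F)F)c2)c1` differs from compound 3 by isopropyl in place of hydrogen on an aromatic carbon with isopropyl in place of hydrogen on an aromatic carbon, para to a 3,4-dihydroxyphenoxy group. For the measured compounds named here, the only measured step that bears on this is a 1.1-fold lower number from compound 1 to compound 3 (0.06 log units; within the scatter) for hydrogen in place of methyl on an aromatic carbon. Going by the values given here, no measured step involves isopropyl, so this evidence is thin. Resting on that one small step, no shift beyond the scatter is expected. The estimated step is a 1.1-fold lower number from compound 3 to compound 4 (0.04 log units; within the scatter) for now. Compound 4 is estimated at 4500 nM with a range of 2000 nM to 10000 nM expected for it.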

Compound 4, half-maximal inhibitory concentration: 6800 nM
Compound 4: the middle estimate sits 1.5-fold (0.18 log units) below what was measured; low and high end bracket the measured number.
By their numbers in this assay, from the lowest: compounds 3, 1, 2 and 4 (each within the scatter of the next).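

In this assay, isopropyl on the aromatic carbon para to a 3,4-dihydroxyphenoxy group gives a 1.4-fold higher number from compound 3 to compound 4 (0.14 log units; within the scatter). This carbon therefore carries a group of three carbons in place of hydrogen with no shift that can be told from the usual scatter of repeated measurements. No measurement shown offers an explanation for this result.

The compounds shown leave open what an amine, a carboxylic acid or a longer alkyl chain on this carbon would do. Going by these compounds, whether any group here can move the number beyond the scatter also remains open.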